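Swapping a Side Chain on a Shared Purine-Type Core

A few compounds are considered here, and "the series" means these few. Any claim that something is new, unique, unknown or untested is made for them only; others in the source may bear on it.

Measured so far:
Compound 1, `O=C(OCc1ccccc1)[C@@H]1CCCN1C(=O)CN(c1nc(Cl)nc2[nH]cnc12)C1CC1`: 33.2%
Compound 2, `CC[C@H](C)[C@H](NC(=O)CN(c1nc(Cl)nc2[nH]cnc12)C1CC1)C(=O)OCc1ccccc1`: 41.4%
Compound 3, `NC(=O)CC[C@H](NC(=O)CN(c1ncnc2c1ncn2C1CCCCO1)C1CC1)C(=O)OCc1ccccc1`: 47%

All three compounds were tested in a functional assay on the whole organism (Tail, strain ICR) with Mus musculus as the target, in the tail flick test, with a stated time of 30 min, at a dose of 25 umol/kg by the oral route; on this read-out higher numbers stand for a stronger effect at the one dose given and lower numbers for a weaker effect. On the numbers shown, compound 2 stands second highest of three. Its nearest neighbour is compound 3, whose value lies within the scatter of it; its furthest is compound 1, whose value also lies within the scatter. The three values therefore cannot be ranked against each other.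

The next compound, compound 4, `NC(=O)C[C@H](NC(=O)CN(c1nc(Cl)nc2[nH]cnc12)C1CC1)C(=O)OCc1ccccc1`, keeps the core and the ester of compound 2 and alters only one place: carbamoylmethyl in place of sec-butyl on a saturated chain carbon bound to an amide-type nitrogen and a carbonyl carbon. Going by the values given here, no measured pair shows the effect of this exact swap, so the expectation rests on the spread of the three values, which is narrow. A step of no more than the usual scatter is expected, in either direction, in this assay. The estimated step is a number 2.6 percentage points higher from compound 2 to compound 4 (within the scatter). Compound 4 is expected to give about 44%, with a plausible range from 30% to 58%.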

Compound 4, a percentage reported as activity, at one dose (the size of the read-out at that dose, not a potency): 24.4%
Compound 4: middle estimate off by 19.6 percentage points, on the high side; the whole stated range lies above it.
By their numbers in this assay, from the lowest: compounds 4, 1, 2 and 3 (each within the scatter of the next, the first and the last beyond it).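

In this assay, going by these compounds alone, this position is not indifferent: carbamoylmethyl in place of sec-butyl on a saturated chain carbon bound to an amide-type nitrogen and a carbonyl carbon gives a number 17 percentage points lower from compound 2 to compound 4 (beyond the scatter) and thus a step beyond the scatter, which the earlier compounds could not show, as none of them differed in only one place. Both groups hold 4 heavy atoms, so the heavy-atom count stays the same while the make-up changes: the entering group brings nitrogen, oxygen, 1 hydrogen-bond donor and 1 hydrogen-bond acceptor. Nothing given here explains the lower number.

This single swap cannot show which part of the carbamoylmethyl group matters. Also open, as far as these compounds go, is how a carboxylic acid or an amine would compare at this place on the same core.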